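Trifluoromethyl for Methyl on Two Related Ester Cores

The compounds below may be only part of what the source reports. "The series", "measured", "known", "first", "only" and "open" are said of these compounds alone.

Compound 1 `Cc1ccccc1OC(=O)c1coc(-c2ccccc2)n1` and compound 2 `O=C(Oc1ccccc1C(F)(F)F)c1coc(-c2ccccc2)n1` differ only by trifluoromethyl in place of methyl on an aromatic carbon. In an ADME assay on microsomes from liver (Rattus norvegicus, strain Sprague-Dawley) for metabolic stability, read by LC-MS, with a stated time of 15 min, tested at 20 uM (on this read-out higher numbers stand for a more stable compound and lower numbers for a less stable compound), compound 1 gives 13.4%, and compound 2 gives 10.7%, so the step is a number 2.7 percentage points lower from compound 1 to compound 2 (within the scatter). Compound 3 `Cc1ccccc1COC(=O)c1coc(-c2ccccc2)n1` carries a core whose difference from the core of compound 1 is not broken down here; in this assay compound 3 gives 10.9%. Compound 4 `O=C(OCc1ccccc1C(F)(F)F)c1coc(-c2ccccc2)n1` differs from compound 3 by trifluoromethyl in place of methyl on an aromatic carbon, the same change at the same kind of place as before. A step of similar size is expected, because the earlier step of a number 2.7 percentage points lower from compound 1 to compound 2 (within the scatter) stayed within the scatter. In this assay the expected step is a number 1.9 percentage points lower from compound 3 to compound 4 (within the scatter). For compound 4 the estimate in this assay is 9%, expected to lie between 3% and 18%.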

Compound 4, percent of the compound remaining in the Rattus norvegicus assay: 7.8%
The estimate for compound 4 lay 1.2 percentage points above the measured number; the measured number falls inside the stated range.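

In the Rattus norvegicus assay compound 3 gives 10.9% and compound 4 gives 7.8%, which is a number 3.1 percentage points lower from compound 3 to compound 4 (within the scatter) for trifluoromethyl in place of methyl and so reads much as it did on the core of compound 1: the same change on two cores in the Rattus norvegicus assay, a number 2.7 percentage points lower (within the scatter) from compound 1 to compound 2 and a number 3.1 percentage points lower (within the scatter) from compound 3 to compound 4, 0.4 percentage points apart, within the scatter of two such steps. In a physicochemical assay for metabolic stability, read by LC-MS, in simulated gastric fluid, with a stated time of 15 min, tested at 50 uM (a higher number here means that more of the compound is left, a lower number that less of the compound is left), compound 3 gives 3.1% and compound 4 gives 0.8%, which is a number 2.3 percentage points lower from compound 3 to compound 4 (within the scatter) for the same change on this second core. Going by these compounds alone, with only two pairs and every step within the scatter, this shows that the change carried from one core to the other without a visible difference, but not that trifluoromethyl really lowers these numbers, nor that further cores would follow.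

The compounds shown leave open how other groups at this place, such as a chlorine atom, a nitrile or an amine, would read. They also leave open whether an amide in place of the ester would read differently.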